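A few compounds are considered here, and "the series" means these few. Any claim that something is new, unique, unknown or untested is made for them only; others in the source may bear on it.

Measured compounds in the series:

compound 1, `Cc1ccc(C(O)c2cc(Cl)ccc2OCC(=O)Nc2ccc(S(N)(=O)=O)cc2C)cc1`: 38700 nM
compound 2, `Cc1cc(C)cc(C(O)c2cc(Cl)ccc2OCC(=O)Nc2ccc(S(N)(=O)=O)cc2C)c1`: 29400 nM

In an ADME assay on C8166 cells (Homo sapiens) for cytotoxicity, read by MTT assay (on this read-out lower numbers stand for higher toxicity in this test and higher numbers for lower toxicity in this test), compound 1 gives 38700 nM and compound 2 gives 29400 nM. For the measured compounds named here, the step between them, a 1.3-fold lower number from compound 1 to compound 2 (0.12 log units; within the scatter), is the only measured step in the set. Compound 2 stands lowest of the two numbers, but its nearest neighbour, compound 1, lies within the scatter of it, so no order between the two can be claimed.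

Compound 3, `Cc1cc(S(N)(=O)=O)ccc1NC(=O)COc1ccc(Cl)cc1C(O)c1ccc2ccccc2c1`, is not yet measured in this assay. It differs from compound 2 as follows: naphthalen-2-yl in place of 3,5-dimethylphenyl on a saturated chain carbon bound to an aromatic carbon and an oxygen on a saturated carbon. Going by the values given here, the only step that bears on a change at this place is a 1.3-fold lower number from compound 1 to compound 2 (0.12 log units; within the scatter), which was within the scatter; nothing measured here separates one aryl group at this position from another. The expectation for compound 3 is therefore a step of about a 1.2-fold lower number from compound 2 to compound 3 (0.09 log units; within the scatter), with no change beyond the scatter. The estimated value for compound 3 is 24000 nM, in the range 10000 nM to 60000 nM.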

Compound 3, half-maximal cytotoxic concentration: 15700 nM
For compound 3 the middle estimate is 1.5-fold (0.18 log units) above the measured one; the measured number falls inside the stated range.
By their numbers in this assay, from the lowest: compounds 3, 2 and 1 (each within the scatter of the next, the first and the last beyond it).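

In this assay, this position now shows a step beyond the scatter (a 2.5-fold lower number from compound 1 to compound 3 (0.39 log units; beyond the scatter)), a modest one, with naphthalen-2-yl in place of 4-methylphenyl. With naphthalen-2-yl in place of 3,5-dimethylphenyl, the step (a 1.9-fold lower number from compound 2 to compound 3 (0.27 log units; within the scatter)) stays within the scatter, so compound 2 cannot be separated from compound 1 or compound 3, and the aryl group at this place matters only between the two ends of this short set. Nothing available here accounts for the difference.

From the compounds shown here alone, whether the number at this place responds to the second aromatic ring of naphthalen-2-yl or simply to the larger count of carbon atoms remains open. Also open, going by these compounds, is how a cyclohexyl group, an amine or a carboxylic acid on the same saturated chain carbon would read in this assay.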